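The source may hold more compounds than are shown below. What is called first, only, known or untested is meant among the compounds shown, and "the series" means these compounds.

Compound 1 `Cc1ccc(-c2nc(NN)c3cc(Cl)ccc3n2)cc1`: 3.98 ug/mL
Compound 2 `Cc1ccc(-c2nc3ccc(Cl)cc3c(=O)n2N)cc1`: 12.1 ug/mL
Compound 3 `Cc1ccc(C(=O)Nc2ccc(Cl)cc2C(=S)NN)cc1`: 4.98 ug/mL

The three measured compounds were tested in a functional assay on HeLa cells (Homo sapiens) for antiproliferative activity, read by MTT assay, with a stated time of 48 h; on this read-out higher numbers stand for weaker inhibition and lower numbers for stronger inhibition. Compound 1 gives the lowest number of the three; compound 3 lies within the scatter of it, while compound 2 sits beyond the scatter with a higher number. Compound 4 `Cc1ccc(-c2nc(SCCO)c3cc(Cl)ccc3n2)cc1` is the unmeasured analogue of compound 1, differing in one place: (2-hydroxyethyl)sulfanyl in place of aminoamino on an aromatic carbon. No step between measured compounds follows this kind of change, so the direction is not anchored by the data shown. The expectation is a modest step in this assay toward weaker inhibition, a 2.0-fold higher number from compound 1 to compound 4 (0.30 log units; within the scatter), though a step within the scatter is also plausible. Compound 4 is estimated at 8 ug/mL, within a range from 3 ug/mL to 25 ug/mL.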

Compound 4, half-maximal inhibitory concentration: 9.25 ug/mL
Estimate against measurement, compound 4: 1.2-fold (0.06 log units) below; measured number inside the range.
By their numbers in this assay, from the lowest: compounds 1, 3, 4 and 2 (each within the scatter of the next, the first and the last beyond it).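

In this assay, among these compounds, the step at this aromatic carbon next to the ring nitrogen is the first that can be read: (2-hydroxyethyl)sulfanyl in place of aminoamino gives a 2.3-fold higher number from compound 1 to compound 4 (0.37 log units; beyond the scatter) as a modest weakening. The position therefore responds to this change, yet inhibition remains measurable, with compound 4 at 9.25 ug/mL in this assay. Nothing shown accounts for the step. On these data alone, whether it follows from the sulfur link, the hydroxyl end or the chain itself stays open. A methylsulfanyl or a (2-hydroxyethyl)amino group on this carbon would separate these.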